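The source may report more compounds than this note shows. Statements on the series, on what has been measured and on what is new or still open speak of the compounds shown alone.

Of the compounds shown here, three of a shared core have been measured in an assay on isolated protein (strain albino) for antagonist activity at Voltage-dependent L-type calcium channel subunit alpha-1C (Cavia porcellus); a higher number here means a weaker inhibitor, a lower number a stronger inhibitor. Compound 1 (`CSc1ncc(C2C(C(=O)OC3CCCC3)=C(C)NC(C)=C2C(=O)OC2CCCC2)n1Nc1ccccc1`), which carries two cyclopentyl esters, gives 425 nM. Compound 2 (`COC(=O)C1=C(C)NC(C)=C(C(=O)OC)C1c1cnc(SC)n1Nc1ccccc1`), with two methyl esters, gives 3.54 nM. Compound 3 (`CSc1ncc(C2C(C(=O)OCCc3ccccc3)=C(C)NC(C)=C2C(=O)OCCc2ccccc2)n1Nc1ccccc1`), with two phenethyl esters, gives 2.79 nM. Among these three numbers compound 2 stands second highest; its number lies close to that of compound 3, a difference within the usual scatter, while compound 1 sits far above both, a gap well beyond the scatter.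

Compound 4 (`COC(=O)C1=C(C)NC(C)=C(C(=O)OCc2ccccc2)C1c1cnc(SC)n1Nc1ccccc1`) has not yet been measured. It differs from compound 2 in one place: phenyl in place of hydrogen on a saturated chain carbon bound to an oxygen next to a carbonyl group. One of the two methyl esters thus becomes a benzyl ester while the other is unchanged. Within the data shown here, no single-change step between measured compounds is available to guide this. What the numbers show is that compound 2 and compound 3, which differ in both ester groups, give values within the scatter of each other, so a larger ester carrying a phenyl ring did not move the number in that pair. The expected step from compound 2 to compound 4 in this assay is therefore a 1.1-fold lower number from compound 2 to compound 4 (0.04 log units; within the scatter), none beyond the scatter. Compound 4 is estimated at 3.2 nM, within a range of 1 nM to 10 nM.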

Compound 4, half-maximal inhibitory concentration: 2.21 nM
The estimate for compound 4 lay 1.4-fold (0.16 log units) above the measured number; low and high end bracket the measured number.
By their numbers in this assay, from the lowest: compounds 4, 3 and 2 (each within the scatter of the next); then compound 1.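

Among these compounds, this is the first reading of a change at one ester alone: phenyl in place of hydrogen on a saturated chain carbon bound to an oxygen next to a carbonyl group, which turns methoxycarbonyl into benzyloxycarbonyl while the other methyl ester stays as it is. In this assay this swap reads a 1.6-fold lower number from compound 2 to compound 4 (0.20 log units; within the scatter) and so cannot be told apart from the ordinary spread of repeat measurements. The earlier compounds shown here carried the same ester twice and differed from each other at both ester positions, so they could not show what one ester does alone; this pair shows that a methyl ester can give way to a benzyl ester, adding a six-membered aromatic ring, with no readable change in this assay.

As far as these compounds go, it remains open how this position would respond to a carboxylic acid, to a chain ending in an amine, or to a longer chain on one side only, such as a single phenethyl ester. Nothing measured here accounts for the flat result, and no reason for it can be offered.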